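This account rests on a few compounds, and the source may have more. Where it says the series, first, only, none or still open, it means among the compounds named here.

In a functional assay on HL-60 cells (Homo sapiens) for cytotoxicity, read by MTT assay, with a stated time of 24 h (on this read-out lower numbers stand for stronger inhibition and higher numbers for weaker inhibition), compound 1 `COc1ccccc1N1CCN(CCCCCOc2c(Br)cc(Br)cc2Oc2ccc(Br)cc2Br)CC1` gives 32.2 ug/mL, the higher of the two numbers shown, while compound 2 `C=CCOc1c(Br)cc(Br)cc1Oc1ccc(Br)cc1Br` gives 27.9 ug/mL; the gap between them lies within the scatter, so neither can be called stronger. Compound 3 `Brc1ccc(Oc2cc(Br)cc(Br)c2OCCCCCN2CCN(C/C=C/c3ccccc3)CC2)c(Br)c1` differs from compound 1 in one place: 3-phenylprop-2-en-1-yl in place of 2-methoxyphenyl on an amine nitrogen in a ring. Within the data shown here, no step between measured compounds bears on this change, so no shift beyond the scatter is expected in this assay. The estimated step of a 1.1-fold lower number from compound 1 to compound 3 (0.03 log units; within the scatter) is thus expected to stay inside the scatter. Compound 3 is expected to give about 30 ug/mL, in a range from 12 ug/mL to 75 ug/mL.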

Compound 3, half-maximal inhibitory concentration: 47.2 ug/mL
Compound 3: the middle estimate sits 1.6-fold (0.20 log units) below what was measured; measured number inside the range.
By their numbers in this assay, from the lowest: compounds 2, 1 and 3 (each within the scatter of the next).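

At the amine nitrogen in the ring, 3-phenylprop-2-en-1-yl in place of 2-methoxyphenyl gives a 1.5-fold higher number from compound 1 to compound 3 (0.17 log units; within the scatter) in this assay. This position therefore takes a change from one group carrying an aromatic ring to another, here losing the oxygen and gaining a double bond, without a shift that stands out from the scatter. Nothing available bears on why this is so. Still open, going by these compounds, is whether a group without an aromatic ring, such as methyl or acetyl, on this nitrogen would move the number beyond the scatter. Among these compounds, a shorter or longer chain than the one shared by compound 1 and compound 3 also remains open.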